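Swapping amino for methyl on the sulfonyl of a weak series

The source may report more compounds than this note shows. Statements on the series, on what has been measured and on what is new or still open speak of the compounds shown alone.

Compound 1, `Cc1cnc(Nc2ccc(S(C)(=O)=O)cc2)nc1Nc1nc2ccc(Cl)cc2s1`: 4320 nM
Compound 2, `Cc1cnc(Nc2ccc(S(N)(=O)=O)cc2)nc1Nc1nc2ccc(Cl)cc2s1`: 8430 nM
Compound 3, `COc1ccc2nc(Nc3nc(Nc4ccc(S(N)(=O)=O)cc4)ncc3F)sc2c1`: > 50000 nM

In a functional assay on MCF7 cells (Homo sapiens) for antiproliferative activity, read by MTT assay, with a stated time of 48 h (on this read-out higher numbers stand for weaker inhibition and lower numbers for stronger inhibition), compound 2 gives 8430 nM and compound 1 gives 4320 nM. The change between them, (methyl in place of amino on a sulfonyl sulfur), is measured as a 2.0-fold lower number from compound 2 to compound 1 (0.29 log units; within the scatter). In this assay compound 3 gives only a limit, > 50000 nM. The difference between the core of compound 2 and the core of compound 3 is not broken down here. Compound 4, `COc1ccc2nc(Nc3nc(Nc4ccc(S(C)(=O)=O)cc4)ncc3F)sc2c1`, is not yet measured; it carries the same change relative to compound 3, namely (methyl in place of amino on a sulfonyl sulfur). Because compound 3 sits at the limit of > 50000 nM in this assay, at which 1 of the 3 values shown sits, and because the measured step of a 2.0-fold lower number from compound 2 to compound 1 (0.29 log units; within the scatter) is within the scatter, compound 4 is expected to stay near that limit, with an estimated step that the limit leaves unreadable from compound 3 to compound 4. Compound 4 is therefore expected to give about 60000 nM, between 20000 nM and 200000 nM.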

Compound 4, half-maximal inhibitory concentration: 5850 nM
Compound 4: the middle estimate sits 10-fold (1.01 log units) above what was measured; the measured number lies below the stated range.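

In this assay, putting methyl in place of amino on the sulfonyl sulfur gives an at least 8.5-fold lower number from compound 3 to compound 4 (0.93 log units; beyond the scatter). The size of this change therefore does not carry over unchanged from one core to the other: the same change on two cores in this assay, a 2.0-fold lower number (0.29 log units; within the scatter) from compound 2 to compound 1 and an at least 8.5-fold lower number (0.93 log units; beyond the scatter) from compound 3 to compound 4, at least 4.3-fold (0.64 log units) apart, beyond the scatter of two such steps

Compound 3 gives > 50000 nM, which is a limit and not a number, so the result shows only the smallest possible size of its step and not the true size. Which part of the core sets the gap between the two steps remains open. Also open, going by these compounds, is how a longer chain such as ethyl, or a dimethylamino group, would behave on the sulfonyl sulfur of either core.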